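Dimethylamino in Place of Acetyl: What the Numbers Suggest

This account rests on a few compounds, and the source may have more. Where it says the series, first, only, none or still open, it means among the compounds named here.

Of the compounds shown here, three sharing one core have been tested in a functional assay on UACC-257 cells (Homo sapiens) for cytotoxicity, read by sulforhodamine B assay, with a stated time of 48 h, tested at 0.001 uM; on this read-out lower numbers stand for a stronger effect and higher numbers for a weaker effect at the one concentration tested. In this assay compound 1 `COc1cc(C)cc(-c2c(-c3ccnc(-c4ccc(C(C)=O)cc4)c3)cnn2CC#N)c1` gives 95%. Compound 2 `Cc1cc(O)cc(-c2nn(CC#N)cc2-c2ccnc(-c3ccc(Oc4ccccc4)cc3)c2)c1` gives 95%, and compound 3 `Cc1cc(O)cc(-c2nn(CC#N)cc2-c2ccnc(-c3ccc(N(C)C)cc3)c2)c1` gives 96%. Compound 1 thus stands level with compound 2 at the digits reported, the two together forming the lowest of the three numbers; its nearest neighbour is compound 2, with no change at the digits reported, and its furthest is compound 3, one point higher, within the scatter.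

Compound 4 `COc1cc(C)cc(-c2c(-c3ccnc(-c4ccc(N(C)C)cc4)c3)cnn2CC#N)c1` differs from compound 1 in a single place: dimethylamino in place of acetyl on an aromatic carbon. The group enters on an aromatic carbon of a six-membered aromatic ring of carbon only, para to a large group. Among the compounds with values here, only one measured step bears on this change, and only in part, since it brings in the same dimethylamino group but removes phenoxy rather than acetyl: it gave a number 1 percentage points higher from compound 2 to compound 3 (within the scatter). With all three numbers so close to one another, no step beyond the scatter is expected in this assay.

Compound 4 is therefore expected to give 95%, between 88% and 100%, which amounts to an estimated step of no change at the digits printed from compound 1 to compound 4 (within the scatter).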

Compound 4, a percentage reported as activity, at one concentration (the size of the read-out at that concentration, not a potency): 89%
The estimate for compound 4 lay 6 percentage points above the measured number, within the range that was stated.
By their numbers in this assay, from the lowest: compounds 4, 1, 2 and 3 (each within the scatter of the next).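

In this assay, within the data shown here, the exchange of acetyl for dimethylamino, read directly for the first time, gives a number 6 percentage points lower from compound 1 to compound 4 (within the scatter), so 4-acetylphenyl and 4-(dimethylamino)phenyl cannot be told apart at this position. The earlier step at this aromatic carbon had dimethylamino replacing phenoxy, so this result extends the comparison to a second departing group, and here too the step stays within the scatter: neither acetyl nor phenoxy, when replaced by dimethylamino, gives a step that can be separated from the scatter of repeated measurements. No measurement offered here explains the result or shows how either group acts at this position.

The compounds shown leave open whether a carboxylic acid, a primary amine or a longer chain ending in an amine on this same aromatic carbon would give a step beyond the scatter. With only one concentration in the read-out, they also leave open whether acetyl and dimethylamino would still be indistinguishable at higher concentrations, where a larger effect might be seen.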